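Swapping the Ethylamino Group for a Methylpiperazine Ring

The compounds below may be only part of what the source reports. "The series", "measured", "known", "first", "only" and "open" are said of these compounds alone.

Measured compounds:
compound 1 `O=S(=O)(Nc1ccc(CNc2nc(NC3CC3)nc3ccccc23)cc1)c1ccc(F)cc1`: 4900 nM
compound 2 `CCCNc1nc(NCc2ccc(NC(=O)c3ccc(F)cc3)cc2)c2ccccc2n1`: 1700 nM
compound 3 `CCNc1nc(NCc2ccc(NC(=O)c3ccc(F)cc3)cc2)c2ccccc2n1`: 1400 nM

In a functional assay on HCT-116 cells (Homo sapiens) for inhibition, read by luminescence and resazurin assay, with a stated time of 3 days (a lower number here means a stronger inhibitor, a higher number a weaker inhibitor), compound 3 gives the lowest number of the three. Its nearest neighbour is compound 2, and the step of a 1.2-fold lower number from compound 2 to compound 3 (0.08 log units; within the scatter) lies within the scatter; compound 1 sits furthest away, beyond the scatter. Compound 4 `CN1CCN(c2nc(NCc3ccc(NC(=O)c4ccc(F)cc4)cc3)c3ccccc3n2)CC1` differs from compound 3 by 4-methylpiperazin-1-yl in place of ethylamino on an aromatic carbon. For the measured compounds named here, the only measured step, a 1.2-fold lower number from compound 2 to compound 3 (0.08 log units; within the scatter), concerns chain length on the same amino group and says little about replacing that group with a ring. Going by the values given here, no measured pair shows such a change, so the direction is open; a modest rise in the number seems as likely as none. Compound 4 is therefore expected to give about 2500 nM, within 800 nM to 8000 nM, a step of a 1.8-fold higher number from compound 3 to compound 4 (0.25 log units; within the scatter).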

Compound 4, half-maximal inhibitory concentration: 1800 nM
Compound 4: the middle estimate sits 1.4-fold (0.14 log units) above what was measured; low and high end bracket the measured number.
By their numbers in this assay, from the lowest: compounds 3, 2 and 4 (each within the scatter of the next); then compound 1.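

In this assay, the steps of a 1.3-fold higher number from compound 3 to compound 4 (0.11 log units; within the scatter) and a 1.1-fold higher number from compound 2 to compound 4 (0.02 log units; within the scatter) show that this aromatic carbon between two ring nitrogen atoms accepts the larger 4-methylpiperazin-1-yl ring in place of either open-chain amino group, with both steps within the scatter. The hydrogen-bond donor of ethylamino is absent from compound 4, yet the number does not move beyond the scatter, and nothing measured explains this. Going by these compounds, whether morpholine or a piperazine bearing a carboxylic acid would hold the number here remains open.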